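The source may report more compounds than this note shows. Statements on the series, on what has been measured and on what is new or still open speak of the compounds shown alone.

Working notes on the series. Within the data shown here, in a physicochemical assay for lipophilicity, read by HPLC (a higher number here means a more lipophilic compound, a lower number a more polar compound), compound 1 `Cc1ccc(/C=C2/C(=O)c3ccccc3OC2c2ccccc2)cc1` gives 4.36 and compound 2 `O=C1/C(=C\c2ccc(Cl)cc2)C(c2ccccc2)Oc2ccccc21` gives 4.53 with the two values within the scatter of each other, which leaves compound 2 level with the only other number. Compound 3 `O=C1/C(=C/c2ccc(Cl)cc2)C(c2ccccc2)Oc2ccccc21` has no value yet in this assay and, set against compound 2, shows the two compounds have the same atoms and bonds; at least one stereo element is drawn with a configuration in one of them and without one in the other: 1 of 2 stereo elements differ; a double bond is drawn Z in compound 2 and E in compound 3 with the same atoms and bonds, as a double bond is drawn Z in compound 2 and E in compound 3. Among the measured compounds shown here, no measured pair shows what such a change does to this read-out. The expectation therefore rests on compound 2 at 4.53 and no step beyond the scatter is expected in either direction. The estimated move is a number 0.08 log units lower from compound 2 to compound 3 (within the scatter) and stays within the scatter. For compound 3 the expected value is 4.45 with an estimated range from 4.1 to 4.8 on this read-out.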

Compound 3, partition coefficient: 4.46
For compound 3 the middle estimate is 0.01 log units below the measured one, within the range that was stated.
By their numbers in this assay, from the lowest: compounds 1, 3 and 2 (each within the scatter of the next).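

In this assay, changing the double bond from Z to E gives a number 0.07 log units lower from compound 2 to compound 3 (within the scatter), so the geometry of this double bond does not separate the pair on this read-out. Chloro in place of methyl on an aromatic carbon gives a number 0.10 log units higher from compound 1 to compound 3 (within the scatter), so this exchange does not separate its pair either. One point limits how far the geometry pair can be read: the fact that one of compounds 2 and 3 is drawn with a defined configuration and the other without, at the place where they differ.

As far as these compounds go, whether a group of another kind on that aromatic carbon, such as an amine or a carboxylic acid, would give a step beyond the scatter remains open. Also open, from the compounds shown here alone, is whether the Z and E forms would stay within the scatter of each other with such a group in place of chloro.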